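The source may hold more compounds than are shown below. What is called first, only, known or untested is meant among the compounds shown, and "the series" means these compounds.

Measured compounds:
compound 1, `Fc1ccc(-c2cc(-c3ccc4cc(F)ccc4n3)nn2-c2ccccc2)cc1`, 88.3% in an ADME assay on Huh-7 cells (Homo sapiens) for cytotoxicity, read by XTT assay, with a stated time of 3 days, tested at 20 uM; a lower number here means a stronger effect, a higher number a weaker effect of the compound at the concentration tested
compound 2, `COc1ccc(-c2cc(-c3ccc4cc(F)ccc4n3)nn2-c2ccccc2)cc1`, 95.6%
compound 3, `Fc1ccc(-c2cc(-c3ccc4cc(F)ccc4n3)n(-c3ccccc3)n2)cc1`, 88.1%

Compound 1 and compound 2 share a core and differ by one change, (methoxy in place of fluoro on an aromatic carbon). In this assay this change gave a number 7.3 percentage points higher from compound 1 to compound 2 (within the scatter). Compound 3 is built from the same atoms as compound 1, joined differently; the difference between the two cores is not broken down here. In this assay compound 3 gives 88.1%, close to compound 1 with 88.3%.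

Compound 4, `COc1ccc(-c2cc(-c3ccc4cc(F)ccc4n3)n(-c3ccccc3)n2)cc1`, has not yet been measured. It differs from compound 3 by methoxy in place of fluoro on an aromatic carbon, which is the same change as that from compound 1 to compound 2, at the same place. Among the measured compounds shown here, the one measured instance of this change, a number 7.3 percentage points higher from compound 1 to compound 2 (within the scatter), lay within the scatter, so the expected step is a number 5.9 percentage points higher from compound 3 to compound 4 (within the scatter), resting on that single earlier step. For compound 4 the expected value in this assay is therefore 94%, estimated to fall between 84% and 102%.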

Compound 4, a percentage reported as activity, at one concentration (the size of the read-out at that concentration, not a potency): 104%
The estimate for compound 4 lay 10 percentage points below the measured number, and the stated range ends below it.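

Replacing 4-fluorophenyl with 4-methoxyphenyl on the core of compound 3 gave a number 15.9 percentage points higher from compound 3 to compound 4 (beyond the scatter) in this assay. Set beside the earlier step on the core of compound 1, the new step points the same way, and the gap between the two is no larger than repeated measurements would allow: the same change on two cores in this assay, a number 7.3 percentage points higher (within the scatter) from compound 1 to compound 2 and a number 15.9 percentage points higher (beyond the scatter) from compound 3 to compound 4, 8.6 percentage points apart, within the scatter of two such steps

So, as far as two steps can tell, the change carried over between these two cores, although only the step on the core of compound 3 stands beyond the scatter, and the pair neither fixes a size for the change nor shows that it would hold on any other core.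

The compounds shown carry only fluoro or methoxy at this place, so it remains open how an amine, a carboxylic acid or a longer chain there would read in this assay. Also open, from the compounds shown here alone, is how the change would behave if the other fluoro, shared by all four compounds, gave way to a nitrile.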